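Chloro to hydrogen on the aromatic ring: compound 3

The source may hold more compounds than are shown below. What is called first, only, known or untested is meant among the compounds shown, and "the series" means these compounds.

Of the compounds shown here, two are measured so far. In a functional assay on the whole organism (Ehrlich cells) with Mus musculus as the target, at a dose of 50 mg/kg by the intraperitoneal route (a higher number here means more inhibition at the dose given (going by the name of the read-out), a lower number less inhibition), compound 2 `O=C(NNc1ccccc1)C1CCC(=O)N1S(=O)(=O)c1ccc(Cl)cc1` gives 74.3%, and compound 1 `NNC(=O)C1CCC(=O)N1S(=O)(=O)c1ccc(Cl)cc1` gives 64.9%; the step of a number 9.4 percentage points higher from compound 1 to compound 2 (within the scatter) leaves the pair unseparated. Compound 3 `O=C(NNc1ccccc1)C1CCC(=O)N1S(=O)(=O)c1ccccc1` differs from compound 2 by hydrogen in place of chloro on an aromatic carbon, the same difference cut one bond further out reading 4-chlorophenyl to phenyl. Within the data shown here, the one measured step, phenyl in place of hydrogen on an amine nitrogen, concerns a different part of the shared core and does not bear on a chloro leaving an aromatic carbon; no measured pair shows this change. With nothing to point either way, the expected step in this assay is a number 2.3 percentage points lower from compound 2 to compound 3 (within the scatter), nothing beyond the scatter. Compound 3 is therefore estimated at 72%, within a range of 58% to 85%; no shown step informs this range, so it is kept wide.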

Compound 3, a percentage reported as inhibition, in the whole organism at one dose (the size of the read-out at that dose, not a potency): 79%
Beside the measured number, compound 3's estimate is 7 percentage points below it; measured number inside the range.
By their numbers in this assay, from the lowest: compounds 1, 2 and 3 (each within the scatter of the next, the first and the last beyond it).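

In this assay, hydrogen in place of chloro on an aromatic carbon, para to a large group, gives a number 4.7 percentage points higher from compound 2 to compound 3 (within the scatter), so in this pair the chloro can leave without the two numbers separating. Among these compounds, this is the first reading at the aromatic ring, as the earlier step concerned only the amine nitrogen, and a change at either place has so far stayed within the scatter. Nothing available explains the size of this step.

Still open, from the compounds shown here alone, is whether another group on this aromatic carbon, such as methoxy, nitro or a carboxylic acid, would move the number beyond the scatter. Also open, going by these compounds, is whether the same change behaves alike when the amine nitrogen carries hydrogen instead of phenyl, and how the series reads at other doses.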